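This account rests on a few compounds, and the source may have more. Where it says the series, first, only, none or still open, it means among the compounds named here.

Compound 3 `CSc1cccc(N2CCN(Cc3nc[nH]c3C)C2=O)c1` stands weakest of the three compounds measured in a functional assay (Cavia porcellus) for antagonist activity at Serotonin 3 (5-HT3) receptor (Homo sapiens); a lower number here means a stronger inhibitor, a higher number a weaker inhibitor: compound 3 gives 120 nM, whereas compound 1 `Cc1[nH]cnc1CN1CCN(c2cccc(Cl)c2)C1=O` gives 12 nM and compound 2 `Cc1[nH]cnc1CN1CCN(c2ccccc2)C1=O` gives 26.9 nM. The gaps are beyond the scatter in both directions, a 4.5-fold higher number from compound 2 to compound 3 (0.65 log units; beyond the scatter) and a 10-fold higher number from compound 1 to compound 3 (1.00 log units; beyond the scatter).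

The next step leads to compound 4 `Cc1cccc(N2CCN(Cc3nc[nH]c3C)C2=O)c1`, and the change is methyl in place of methylsulfanyl on an aromatic carbon. For the measured compounds named here, three measured steps bear on it. The step of a 4.5-fold higher number from compound 2 to compound 3 (0.65 log units; beyond the scatter) shows that adding methylsulfanyl to the unsubstituted ring weakens the compound, and the step of a 10-fold higher number from compound 1 to compound 3 (1.00 log units; beyond the scatter) shows that methylsulfanyl is also much less favourable than chloro at this carbon. The step of a 2.2-fold higher number from compound 1 to compound 2 (0.35 log units; beyond the scatter) shows that a chloro at this position is modestly better than hydrogen. Methyl is a smaller group than methylsulfanyl, closer to chloro in size, so the removal of the sulfur is expected to recover a good part of what was lost in going from compound 1 or compound 2 to compound 3. For compound 4 the step of a 3.4-fold lower number from compound 3 to compound 4 (0.54 log units; beyond the scatter) is therefore expected, placing it between compound 1 and compound 2. Compound 4 is estimated at 35 nM, with a range from 12 nM to 100 nM.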

Compound 4, antagonist equilibrium constant: 45.7 nM
Beside the measured number, compound 4's estimate is 1.3-fold (0.12 log units) below it, and the stated range covers the measured number.
By their numbers in this assay, from the lowest: compound 1; then compounds 2 and 4 (each within the scatter of the next); then compound 3.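

Within this assay, replacing methylsulfanyl with methyl recovers part of the loss seen at this carbon (a 2.6-fold lower number from compound 3 to compound 4 (0.42 log units; beyond the scatter)), so that loss does not extend to every carbon-linked group placed here. The methyl-bearing compound cannot be told apart from the unsubstituted one (a 1.7-fold higher number from compound 2 to compound 4 (0.23 log units; within the scatter), within the scatter), whereas chloro keeps a clear advantage over methyl (a 3.8-fold higher number from compound 1 to compound 4 (0.58 log units; beyond the scatter)); among the four groups shown at this carbon, only chloro gives a gain over hydrogen that lies beyond the scatter, and methylsulfanyl alone gives a loss beyond it. Nothing measured here explains why these groups differ.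

The compounds shown leave open how other groups at this carbon, such as bromo, methoxy or an amine, would stand in this assay, and so whether chloro's advantage is particular to that group or shared more widely. They also leave open whether the same order of groups would hold on other carbons of the aromatic ring, since every substituted compound here carries its group at this one place.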